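The compounds below may be only part of what the source reports. "The series", "measured", "known", "first", "only" and "open" are said of these compounds alone.

Measured so far in a functional assay on OVCAR-3 cells (Homo sapiens) for antiproliferative activity, read by spectrophotometry, with a stated time of 2 days; on this read-out higher numbers stand for weaker inhibition of growth and lower numbers for stronger inhibition of growth:
- compound 1 `COc1ccc(C(F)(F)F)cc1Nc1ncc(C(F)(F)F)c(N2Cc3cccc(N(C)S(C)(=O)=O)c3C2)n1`: > 30000 nM
- compound 2 `COc1cc(Nc2ncc(C(F)(F)F)c(N3Cc4cccc(N(C)S(C)(=O)=O)c4C3)n2)cc(OC)c1`: 630 nM
- compound 3 `Cc1cc(Cl)ccc1Nc1ncc(C(F)(F)F)c(N2Cc3cccc(N(C)S(C)(=O)=O)c3C2)n1`: > 30000 nM

Compound 1 gives only a limit in this assay, > 30000 nM. Compound 3 likewise stands only at a limit, > 30000 nM. Going by the values given here, compound 2 is the one member with a number, 630 nM. Among the compounds with values here, the step of an at least 47-fold lower number from compound 1 to compound 2 (1.67 log units; beyond the scatter), a 3,5-dimethoxyphenyl in place of 2-methoxy-5-(trifluoromethyl)phenyl on a nitrogen on an aromatic ring, is the only readable step; the step that the two limits leave unreadable from compound 1 to compound 3 cannot be sized, and an at least 47-fold higher number from compound 2 to compound 3 (1.67 log units; beyond the scatter) shows that a 4-chloro-2-methylphenyl there returns the number to the limit (the limit of > 30000 nM in this assay, at which 2 of the 3 values shown sit).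

Compound 4 `CN(c1cccc2c1CN(c1nc(Nc3ccc(Cl)c(C(F)(F)F)c3)ncc1C(F)(F)F)C2)S(C)(=O)=O` is not yet measured. It differs from compound 1 by 4-chloro-3-(trifluoromethyl)phenyl in place of 2-methoxy-5-(trifluoromethyl)phenyl on a nitrogen on an aromatic ring. Within the data shown here, the aryl group that enters carries no methoxy and shares only a trifluoromethyl with the group that leaves; no measured step has this change, so the expectation rests on the limit of compound 1 and the number of compound 2. The step from compound 1 is expected to be an at least 5.0-fold lower number from compound 1 to compound 4 (0.69 log units; beyond the scatter), in the direction of stronger inhibition but uncertain. Compound 4 is expected to give 6000 nM, between 1000 nM and 30000 nM.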

Compound 4, concentration for 50% growth inhibition: > 50000 nM
Compound 4: no number, only a limit; the forecaster's own chance of this, stated with the estimate: 40%; middle value at least 8.3-fold (0.92 log units) from the limit.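

In this assay compound 4 gives > 50000 nM, a limit and not a number. The step to 4-chloro-3-(trifluoromethyl)phenyl is an at least 79-fold higher number from compound 2 to compound 4 (1.89 log units; beyond the scatter), so a third aryl group on this nitrogen fails to give a number, and among the compounds shown only the 3,5-dimethoxyphenyl of compound 2 gives one, while compound 1 carries a methoxy and still stands at a limit. The steps to compound 4 from compound 1 and from compound 3 join two limits and cannot be read: the limit of > 50000 nM in this assay, at which 1 of the 4 values shown sits.

Open, from the compounds shown here alone, is whether the number of compound 2 needs both methoxy groups, or whether other groups on that phenyl ring, such as a hydroxyl, an amine or a morpholine, would keep it. Also open, going by these compounds, is how compounds 1, 3 and 4 rank against one another, as limits give no order.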